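Para-chloro removal on the aryl group of compound 2

The source may report more compounds than this note shows. Statements on the series, on what has been measured and on what is new or still open speak of the compounds shown alone.

Measured compounds:
Compound 1 `CCSc1sc(-n2nc(C)c(Cc3ccccc3[N+](=O)[O-])c2C(=O)O)nc1-c1ccc(Cl)c(Cl)c1`, 59000 nM
Compound 2 `Cc1nn(-c2nc(-c3ccc(Cl)c(Cl)c3)c(SC(C)C)s2)c(C(=O)O)c1-c1ccc(Cl)cc1`, 2500 nM

In a functional assay on BJAB cells (Homo sapiens) for antiproliferative activity, with a stated time of 4 days (on this read-out lower numbers stand for an effect already at smaller amounts and higher numbers for an effect only at larger amounts of compound), compound 1 gives 59000 nM, while compound 2 gives 2500 nM. Compound 2 thus stands at the lower of the two numbers, and its gap to compound 1 lies well beyond the scatter; no single-point comparison between these two is drawn, as they differ in more than one place.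

Compound 3 `Cc1nn(-c2nc(-c3ccc(Cl)c(Cl)c3)c(SC(C)C)s2)c(C(=O)O)c1-c1ccccc1` has not yet been measured. It differs from compound 2 by hydrogen in place of chloro on an aromatic carbon, that is, 4-chlorophenyl becomes phenyl. Within the data shown here, no measured pair shows such a change here, so the expectation rests only on compound 2 and the change itself. The step from compound 2 to compound 3 in this assay is expected to be small and toward a higher number, a 2.0-fold higher number from compound 2 to compound 3 (0.30 log units; within the scatter), possibly within the scatter. For compound 3 the estimate is 5000 nM, with a range from 1500 nM to 20000 nM.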

Compound 3, half-maximal effective concentration: 3000 nM
Beside the measured number, compound 3's estimate is 1.7-fold (0.22 log units) above it, and the stated range covers the measured number.
By their numbers in this assay, from the lowest: compounds 2 and 3 (each within the scatter of the next); then compound 1.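

In this assay the change of 4-chlorophenyl to phenyl gives a 1.2-fold higher number from compound 2 to compound 3 (0.08 log units; within the scatter) and so shows that, at this place on the aromatic ring, hydrogen can stand in for chloro without a difference that can be told from the scatter. Among these compounds, this is the first comparison here that isolates a single place, as compound 1 differs from compound 2 in more than one place and could say nothing about this chloro group alone. Nothing at hand accounts for the two numbers lying so close.

Still open, on these data alone, is whether another group at this place, such as an amine, a methoxy group or a carboxylic acid, would stand apart from compound 2 and compound 3. Also open is whether hydrogen in place of chloro would read the same on the other aromatic ring, which keeps its two chloro groups in all the compounds shown.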